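Chloro for dimethylamino on the aryl vinyl sulfide series

The source may hold more compounds than are shown below. What is called first, only, known or untested is meant among the compounds shown, and "the series" means these compounds.

Measured compounds:
compound 1 `Cc1ccc(S/C(=C/c2ccc(Cl)cc2)C(=O)c2ccc(Br)cc2)cc1`, 10000 nM
compound 2 `Cc1ccc(S/C(=C/c2ccc(N(C)C)cc2)C(=O)c2ccc(Br)cc2)cc1`, > 100000 nM
compound 3 `Cc1ccc(CS/C(=C/c2ccc(N(C)C)cc2)C(=O)c2ccc(Cl)cc2)cc1`, > 100000 nM

Three compounds are measured in a functional assay on DU-145 cells (Homo sapiens) for inhibition, read by trypan blue exclusion, with a stated time of 96 h; on this read-out lower numbers stand for stronger inhibition of growth and higher numbers for weaker inhibition of growth. Compound 1 gives 10000 nM. For compound 2 the assay reports only a limit, > 100000 nM. For compound 3 likewise only a limit is reported, > 100000 nM. The change from compound 2 to compound 1 is chloro in place of dimethylamino on an aromatic carbon, and it gives an at least 10-fold lower number from compound 2 to compound 1 (1.00 log units; beyond the scatter); the size is known only as a bound because of the limit of > 100000 nM in this assay, at which 2 of the 3 values shown sit.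

Compound 4 `Cc1ccc(CS/C(=C/c2ccc(Cl)cc2)C(=O)c2ccc(Cl)cc2)cc1` is not yet measured. It stands to compound 3 as compound 1 stands to compound 2: the change is chloro in place of dimethylamino on an aromatic carbon, the same change at the same place. The difference between the core of compound 3 and the core of compound 2 is not broken down here.

The step from compound 3 to compound 4 in this assay is expected to be an at least 6.6-fold lower number from compound 3 to compound 4 (0.82 log units; beyond the scatter), resting on the step from compound 2 to compound 1 and on the limit of compound 3. Compound 4 is therefore estimated at 15000 nM, between 3000 nM and 100000 nM.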

Compound 4, concentration for 50% growth inhibition: 10000 nM
Beside the measured number, compound 4's estimate is 1.5-fold (0.18 log units) above it, within the range that was stated.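

In this assay chloro in place of dimethylamino gives an at least 10-fold lower number from compound 3 to compound 4 (1.00 log units; beyond the scatter) and so points the same way on the core of compound 4 as on the core of compound 1. Set side by side, the two steps read: the same change on two cores in this assay, an at least 10-fold lower number (1.00 log units; beyond the scatter) from compound 2 to compound 1 and an at least 10-fold lower number (1.00 log units; beyond the scatter) from compound 3 to compound 4; the limit leaves it open whether they differ
The direction therefore holds on these two cores, but the size of the step on either core remains unfixed because of the assay limit: the limit of > 100000 nM in this assay, at which 2 of the 4 values shown sit.

Open, as far as these compounds go, is whether a fluoro group, a methoxy group or a carboxylic acid at this place would give a number like that of chloro. Also open, from the compounds shown here alone, is how the change behaves with a longer chain on the sulfur.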